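A Smaller Heteroaryl on the Sulfonyl Sulfur

A few compounds are considered here, and "the series" means these few. Any claim that something is new, unique, unknown or untested is made for them only; others in the source may bear on it.

Of the compounds shown here, two have been measured in a functional assay (trachea) for antagonist activity, with Cavia porcellus as the target; a lower number here means a less potent compound, a higher number a more potent compound, by a factor of ten per unit of this negative logarithm. Compound 1, `COc1cc(C(=O)NS(=O)(=O)c2ccc3ccccc3c2)ccc1Cn1ccc2ccc(NC(=O)CC3CCCC3)cc21`, gives 8.3 in this assay. Among the measured compounds shown here, compound 2, `CCCCC(CC)C(=O)Nc1ccc2ccn(Cc3ccc(C(=O)NS(=O)(=O)c4ccccc4C)cc3OC)c2c1`, gives 8.9 in this assay, so compound 1 stands lowest of the two numbers known, with compound 2 higher by a gap that lies beyond the usual scatter. For the measured compounds named here, the two structures differ in more than one place, so no single step between them is drawn.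

Compound 3, `COc1cc(C(=O)NS(=O)(=O)c2ccccn2)ccc1Cn1ccc2ccc(NC(=O)CC3CCCC3)cc21`, has not been measured. It differs from compound 1 in one place: pyridin-2-yl in place of naphthalen-2-yl on a sulfonyl sulfur. Going by the values given here, no measured pair in the set mirrors this exchange, so the size of the step rests on judgement alone. A modest decrease in this assay is expected, close to the edge of the scatter, as the group that enters is much smaller than the one that leaves. For compound 3 the expected value in this assay is 8, with a range from 7.3 to 8.7. This expectation corresponds to a step of a number 0.30 log units lower from compound 1 to compound 3 (within the scatter).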

Compound 3, negative logarithm of the antagonist equilibrium constant: 8.9
Estimate against measurement, compound 3: 0.90 log units below, outside the stated range (above it).
By their numbers in this assay, from the lowest: compound 1; then compounds 2 and 3 (each within the scatter of the next).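

In this assay, pyridin-2-yl in place of naphthalen-2-yl on a sulfonyl sulfur gives a number 0.60 log units higher from compound 1 to compound 3 (beyond the scatter), the first single change read at this position. The position therefore does not depend on naphthalen-2-yl: a smaller group, with one six-membered aromatic ring holding a hetero atom, stands here with a gain beyond the scatter on the same core. Nothing available bears on why this exchange raises the number.

The step changes size and ring content together, so it leaves open whether the gain follows the smaller group or the ring nitrogen. Plain phenyl on the same sulfur would bear on the first, while pyridin-3-yl, with the ring nitrogen moved, would show whether its place in the ring matters.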